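Fluoro in Place of Hydrogen: Expecting Compound 3's Cytotoxicity

The source may report more compounds than this note shows. Statements on the series, on what has been measured and on what is new or still open speak of the compounds shown alone.

Measured compounds:
compound 1, `COc1ccc(-c2cc(C(C)=O)c3[nH]c(-c4ccc(F)cc4)cc3c2)cc1`: 74.5%
compound 2, `CC(=O)c1cc(/C=C/c2ccc(F)cc2)cc2cc(-c3ccccc3)[nH]c12`: 74.2%

Of the compounds shown here, two have been tested in a functional assay on HeLa cells (Homo sapiens) for cytotoxicity, read by MTT assay, with a stated time of 2 days, tested at 0.1 uM; a lower number here means a stronger effect, a higher number a weaker effect of the compound at the concentration tested. In that assay compound 1 gives 74.5%, and compound 2 gives 74.2%. The two numbers lie within the usual scatter of each other, so on these data compound 2 cannot be told apart from compound 1; both leave most of the cells alive at the concentration tested.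

Compound 3, `CC(=O)c1cc(/C=C/c2ccc(F)cc2)cc2cc(-c3ccc(F)cc3)[nH]c12`, has not yet been measured. Its difference from compound 2 is small: fluoro in place of hydrogen on an aromatic carbon. Among the measured compounds shown here, no pair of measured compounds shows the effect of this particular change, so there is no measured step to lean on. With only one heavy atom entering and no hydrogen-bond donor or acceptor added, the expectation is that the step from compound 2 to compound 3 in this assay stays within the scatter, in no firm direction, that is, an expected a number 1.2 percentage points lower from compound 2 to compound 3 (within the scatter). For compound 3 the estimated read-out is therefore 73%, with a likely range from 60% to 86%.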

Compound 3, a percentage reported as activity, at one concentration (the size of the read-out at that concentration, not a potency): 72.6%
The estimate for compound 3 lay 0.4 percentage points above the measured number, within the range that was stated.
By their numbers in this assay, from the lowest: compounds 3, 2 and 1 (each within the scatter of the next).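

In this assay, among the compounds shown here, replacing phenyl with 4-fluorophenyl gives a number 1.6 percentage points lower from compound 2 to compound 3 (within the scatter), which is the first measured view of this change: at this position, on an aromatic carbon para to a large group, fluoro in place of hydrogen does not separate the two compounds. The second step that can now be read, 2-(4-fluorophenyl)ethenyl in place of 4-methoxyphenyl on an aromatic carbon, gives a number 1.9 percentage points lower from compound 1 to compound 3 (within the scatter), so this exchange of a whole substituent cannot be told apart in this assay either. No accompanying measurement helps to explain these results.

The compounds shown leave open whether a different group at the same place on the ring, such as an amine or a carboxylic acid, would shift the read-out beyond the scatter. They also leave open whether fluoro in place of hydrogen would make a visible difference at any concentration other than the single one used in this assay, since most of the cells survive there and the result tells only the size of the effect at that concentration.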